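Amine side chain variation: working notes

A few compounds are considered here, and "the series" means these few. Any claim that something is new, unique, unknown or untested is made for them only; others in the source may bear on it.

Measured so far:
- compound 1 `CN(C)CCCNc1nc(-c2ccc(F)cc2)nc2ccccc12`: 63000 nM
- compound 2 `CN(C)CCNc1nc(-c2ccc(Cl)cc2)nc2ccccc12`: 60000 nM

Both values come from a toxicity assay on cells (Macrophage, Homo sapiens) for inhibition, read by MTT assay; on this read-out higher numbers stand for weaker inhibition and lower numbers for stronger inhibition. Compound 1 shares one level with compound 2, since the two numbers lie within the scatter of each other.

Compound 3 `NCCNc1nc(-c2ccc(F)cc2)nc2ccccc12` has yet to be measured in this assay. Relative to compound 1 it carries amino in place of (dimethylamino)methyl on a saturated chain carbon, two bonds along the chain from a nitrogen on an aromatic ring. The same difference, cut further out, reads 3-(dimethylamino)propyl to 2-aminoethyl.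

Within the data shown here, the series offers no measured step to scale this change, so the expectation is anchored on compound 1 at 63000 nM. A small move toward a lower number is expected, which may not clear the scatter. The expected change is a 1.4-fold lower number from compound 1 to compound 3 (0.15 log units; within the scatter). For compound 3 the estimated value is 45000 nM, with an expected range from 18000 nM to 100000 nM.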

Compound 3, half-maximal inhibitory concentration: 64000 nM
Compound 3: middle estimate off by 1.4-fold (0.15 log units), on the low side; low and high end bracket the measured number.
By their numbers in this assay, from the lowest: compounds 2, 1 and 3 (each within the scatter of the next).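

Amine side chain variation: reading of the step

In this assay, among these compounds, the step from 3-(dimethylamino)propyl to 2-aminoethyl gives a 1.0-fold higher number from compound 1 to compound 3 (0.01 log units; within the scatter), the first direct reading of a change at this position on an otherwise unchanged structure. Exchanging (dimethylamino)methyl, with 4 heavy atoms and 0 hydrogen-bond donors, for amino, with 1 heavy atom and 1 hydrogen-bond donor, therefore leaves no difference that can be told from the scatter. The compounds shown offer no measurement that could explain this flat step.

The step alters chain length and the substitution on the terminal amine together, so the two remain unseparated, and a 3-aminopropyl chain on the core of compound 1 would read the amine substitution at constant length. As far as these compounds go, whether the flat reading extends to a longer chain such as 4-aminobutyl, or to a carboxylic acid at the chain end, remains open.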